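A few compounds are considered here, and "the series" means these few. Any claim that something is new, unique, unknown or untested is made for them only; others in the source may bear on it.

Of the compounds shown here, three describe this series so far. Compound 1 `CC[C@H](C)[C@H](N)CN(C(=O)[C@@H]1C[C@H]1c1nc(C)cs1)c1ccc(-c2ccccc2)cc1` gives 730 nM in a functional assay for agonist activity at G protein-coupled receptor 88 (Homo sapiens), read by HTRF and cAMP accumulation; a lower number here means that less compound is needed, a higher number that more compound is needed for the effect. Compound 2 `CC(C)C[C@H](N)CN(C(=O)[C@@H]1C[C@H]1c1ccccc1)c1ccccc1-c1ccccc1` gives 6200 nM in this assay, and compound 3 `CC(C)C[C@H](N)CN(C(=O)[C@@H]1C[C@H]1c1ccccc1)c1ccc(C2=CCCCCC2)cc1` gives 2100 nM in this assay. Compound 3 thus stands second highest of the three: compound 1 lies nearest, with a lower number, and compound 2 furthest, with a higher number, both gaps beyond the scatter.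

Compound 4 `CC(C)C[C@H](N)CN(C(=O)[C@@H]1C[C@H]1c1ccccc1)c1ccc(-c2ccc(Cl)cc2)cc1` is the next compound to be measured. It differs from compound 3 in one place: 4-chlorophenyl in place of cyclohept-1-en-1-yl on an aromatic carbon. For the measured compounds named here, no measured pair isolates this change, so its size is uncertain. Compound 4 is expected to give a modestly lower number in this assay, a step of a 1.8-fold lower number from compound 3 to compound 4 (0.24 log units; within the scatter), with an estimate of 1200 nM and a range from 400 nM to 3500 nM.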

Compound 4, half-maximal effective concentration: 640 nM
Beside the measured number, compound 4's estimate is 1.9-fold (0.27 log units) above it; the range from low to high includes it.
By their numbers in this assay, from the lowest: compounds 4 and 1 (each within the scatter of the next); then compound 3; then compound 2.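

In this assay, 4-chlorophenyl in place of cyclohept-1-en-1-yl on this aromatic carbon gives a 3.3-fold lower number from compound 3 to compound 4 (0.52 log units; beyond the scatter). This shows that the position responds to the identity of its group, even when the two groups have the same number of heavy atoms. Nothing shown here speaks to what lies behind the step.

Open, on these data alone, is whether the chlorine contributes to the step or the aromatic ring alone suffices. Plain phenyl, 4-fluorophenyl or 4-methoxyphenyl at this place on the core of compound 4 would address that question.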